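The compounds below may be only part of what the source reports. "The series", "measured", "known", "first", "only" and "open" are said of these compounds alone.

Within the data shown here, compound 1 `COc1ccc(COCNc2n[n+]([O-])c3ccccc3[n+]2[O-])cc1` is the weakest of the three compounds measured so far: in a functional assay on PC-3 cells (Homo sapiens) for cytotoxicity, read by MTT assay, with a stated time of 72 h (on this read-out lower numbers stand for stronger inhibition and higher numbers for weaker inhibition), compound 1 gives 52800 nM, the highest number of the three. Compound 2 `CCCOCNc1n[n+]([O-])c2ccccc2[n+]1[O-]` gives 7400 nM in this assay, and compound 3 `CCOCNc1n[n+]([O-])c2ccccc2[n+]1[O-]` gives 7400 nM. The two steps away from compound 1 are alike in size: a 7.1-fold lower number from compound 1 to compound 2 (0.85 log units; beyond the scatter) and a 7.1-fold lower number from compound 1 to compound 3 (0.85 log units; beyond the scatter), while between the two smaller compounds no change at the digits printed from compound 2 to compound 3 (within the scatter). Compound 4 `CC(C)CCOCNc1n[n+]([O-])c2ccccc2[n+]1[O-]` has not yet been measured. It differs from compound 1 in one place: isobutyl in place of 4-methoxyphenyl on a saturated chain carbon bound to an oxygen on a saturated carbon. This change resembles the two measured steps, in that a ring carrying an oxygen gives way to a chain of carbon only, and in both of those steps the number fell by a modest amount. A step of similar size, in the same direction, is therefore expected in this assay: a 7.0-fold lower number from compound 1 to compound 4 (0.85 log units; beyond the scatter). Compound 4 is estimated to give 7500 nM in this assay, with a range from 2500 nM to 25000 nM.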

Compound 4, half-maximal inhibitory concentration: 7520 nM
The estimate for compound 4 lay 1.0-fold (0.00 log units) below the measured number, and the stated range covers the measured number.
By their numbers in this assay, from the lowest: compounds 2, 3 and 4 (each within the scatter of the next); then compound 1.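

With isobutyl in place of 4-methoxyphenyl, this assay shows a 7.0-fold lower number from compound 1 to compound 4 (0.85 log units; beyond the scatter) and so the fall seen with the two straight chains also holds for a branched chain. Isopropyl in place of hydrogen on the chain gives a 1.0-fold higher number from compound 3 to compound 4 (0.01 log units; within the scatter) and isopropyl in place of methyl gives a 1.0-fold higher number from compound 2 to compound 4 (0.01 log units; within the scatter) and so in this assay the three chains stand level at this place. No measurement at hand explains why these chains sit together or why compound 1 stands apart.

The compounds shown leave open whether the ring itself or its methoxy group goes with the higher number of compound 1, a question that a phenyl or a cyclohexyl group at this place could separate. They also leave open whether the level stretch lasts for a longer chain such as octyl, or for a chain ending in an amine or a carboxylic acid.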